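This account rests on a few compounds, and the source may have more. Where it says the series, first, only, none or still open, it means among the compounds named here.

Compound 1 `C[Se]/C(=N\C(=O)c1cc2ccccc2s1)NC(=O)c1cc2ccccc2s1` is one of two compounds that have been tested in an ADME assay on MCF-10A cells (Homo sapiens) for cytotoxicity, read by MTT assay, with a stated time of 72 h; a higher number here means a weaker inhibitor of growth, a lower number a stronger inhibitor of growth. In this assay, going by the values given here, compound 1 gives 34700 nM, the only plain number so far. Compound 2 `CS/C(=N\C(=O)c1ccno1)NC(=O)c1ccno1`, which carries a methylsulfanyl group on its central carbon but different ring parts, reaches only a limit of the assay: in this assay compound 2 gives > 100000 nM. That result, (the limit of > 100000 nM in this assay, at which 1 of the 2 values shown sits), offers nothing to weigh compound 1 against, so compound 1 stands on a single number.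

Compound 3 `CS/C(=N\C(=O)c1cc2ccccc2s1)NC(=O)c1cc2ccccc2s1` differs from compound 1 in one place: a group of 2 heavy atoms (1 carbon, 1 sulfur; no ring) in place of a group of 2 heavy atoms (1 carbon, 1 selenium; no ring), on a carbon with a double bond to nitrogen. Among the compounds with values here, no pair of measured compounds shows this change, so its effect cannot be read from the data. The step is expected to be modest and to stay within the scatter, as a 1.4-fold higher number from compound 1 to compound 3 (0.16 log units; within the scatter). Compound 3 is therefore estimated at 50000 nM, expected to lie between 20000 nM and 150000 nM.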

Compound 3, concentration for total growth inhibition: 5600 nM
Beside the measured number, compound 3's estimate is 8.9-fold (0.95 log units) above it; measured number below the stated range.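

Within the shared core, the group on the carbon with a double bond to nitrogen clearly matters in this assay: putting methylsulfanyl in place of the selenium-carrying group gives a 6.2-fold lower number from compound 1 to compound 3 (0.79 log units; beyond the scatter). Since a lower number means a stronger inhibitor of growth and this step lies beyond the usual scatter, the sulfur-carrying compound is the stronger of this pair, even though the two groups have the same count of heavy atoms. Nothing measured here explains why this exchange has such an effect.

This is a single pair, so it cannot show whether the same exchange would give a similar step with other ring parts. On these data alone, how a longer chain such as ethylsulfanyl, or an amine, would behave on this carbon also remains open.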